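Carbamate capping of the ring amine in a triazole series

This account rests on a few compounds, and the source may have more. Where it says the series, first, only, none or still open, it means among the compounds named here.

Two analogues of the shared core have been run so far: compound 1 `COc1cc(Cn2cc(CSC(=S)N3CCNCC3)nn2)cc(OC)c1OC` and compound 2 `Cc1ccc(Cn2cc(CSC(=S)N3CCNCC3)nn2)cc1`, differing in the substitution of the benzyl portion. In a functional assay on PC-3 cells (Homo sapiens) for inhibition, read by MTT assay, with a stated time of 72 h (on this read-out lower numbers stand for stronger inhibition and higher numbers for weaker inhibition), compound 2 gives 19800 nM. For compound 1 the read-out is only a limit of the assay, not a number: compound 1 gives > 128000 nM. Compound 1 thus sits at the weak end of what has been seen, as recorded by the limit of > 128000 nM in this assay, at which 1 of the 2 values shown sits. Within the data shown here, no pair of measured compounds differs in a single place, so no measured step is available to anchor a trend.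

Compound 3 `COc1cc(Cn2cc(CSC(=S)N3CCN(C(=O)OC(C)(C)C)CC3)nn2)cc(OC)c1OC` is the next analogue. Relative to compound 1 it carries tert-butoxycarbonyl in place of hydrogen on an amine nitrogen in a ring. With compound 1 resting on a limit, the direction of this step cannot be read from the data; the working assumption is a step of modest size, if any, toward lower numbers, with a fair chance that this assay again returns only a limit. The expected step is an at least 1.6-fold lower number from compound 1 to compound 3 (0.20 log units; that floor lies within the scatter). Compound 3 is expected to give 80000 nM in this assay, within a range of 15000 nM to 300000 nM.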

Compound 3, half-maximal inhibitory concentration: > 128000 nM
Compound 3: a limit, no number; the forecaster's own chance of this, stated with the estimate: 45%; middle value at least 1.6-fold (0.20 log units) from the limit.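

Compound 1 and compound 3 both rest on a limit of the assay rather than a number, so no step between them can be read: the limit of > 128000 nM in this assay, at which 2 of the 3 values shown sit.

The compounds shown leave open whether tert-butoxycarbonyl in place of hydrogen on an amine nitrogen in a ring moves this read-out at all, in either direction.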